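Trimethoxyphenyl variant of the pyrazoline sulfonamide series

The source may report more compounds than this note shows. Statements on the series, on what has been measured and on what is new or still open speak of the compounds shown alone.

Two compounds carry numbers. Compound 1 `Cc1cc(O)c(C2=NN(c3ccc(S(N)(=O)=O)cc3)C(c3ccccc3Cl)C2)cc1Cl` gives 16300 nM in a functional assay on SNB-19 cells (Homo sapiens) for antiproliferative activity, with a stated time of 48 h; on this read-out higher numbers stand for weaker inhibition of growth and lower numbers for stronger inhibition of growth. Among the compounds with values here, compound 2 `COc1ccc(C2CC(c3cc(Cl)c(C)cc3O)=NN2c2ccc(S(N)(=O)=O)cc2)cc1OC` gives 89300 nM in this assay, the highest of the two numbers, and the one measured step, a 5.5-fold higher number from compound 1 to compound 2 (0.74 log units; beyond the scatter), is the whole record for this series. Compound 3 `COc1ccc(C2CC(c3cc(Cl)c(C)cc3O)=NN2c2ccc(S(N)(=O)=O)cc2)c(OC)c1OC` carries the change (methoxy in place of hydrogen on an aromatic carbon), on an aromatic carbon ortho to a large group, ortho to a methoxy group and meta to a methoxy group; cut one bond further out it reads 3,4-dimethoxyphenyl to 2,3,4-trimethoxyphenyl. Within the data shown here, no measured step adds a methoxy to an aromatic carbon, so nothing bears on it directly; the only step shows a modest weakening when the aryl group gained methoxy groups, which gives no firm direction for a third. A step within the scatter is therefore expected: compound 3 is estimated at 100000 nM, range 30000 nM to 300000 nM, meaning a 1.1-fold higher number from compound 2 to compound 3 (0.05 log units; within the scatter) in this assay.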

Compound 3, concentration for total growth inhibition: 23900 nM
Compound 3: the middle estimate sits 4.2-fold (0.62 log units) above what was measured; the measured number lies below the stated range.
By their numbers in this assay, from the lowest: compounds 1 and 3 (each within the scatter of the next); then compound 2.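

In this assay, methoxy in place of hydrogen on an aromatic carbon, ortho to a large group, ortho to a methoxy group and meta to a methoxy group, gives a 3.7-fold lower number from compound 2 to compound 3 (0.57 log units; beyond the scatter), so adding a methoxy here does not carry the aryl group further along the weakening seen with 3,4-dimethoxyphenyl. Set against 2-chlorophenyl on the saturated ring carbon, 2,3,4-trimethoxyphenyl gives a 1.5-fold higher number from compound 1 to compound 3 (0.17 log units; within the scatter), whereas 3,4-dimethoxyphenyl gave a 5.5-fold higher number from compound 1 to compound 2 (0.74 log units; beyond the scatter), so a methoxy-bearing aryl group at this carbon need not lie beyond the scatter from the 2-chlorophenyl compound. No available evidence accounts for this step.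

From the compounds shown here alone, whether this aromatic carbon would accept an ethoxy group, a hydroxyl or an amine in place of the methoxy remains open. Also open, going by these compounds, is whether the step depends on the two methoxy groups already on the ring.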